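A few compounds are considered here, and "the series" means these few. Any claim that something is new, unique, unknown or untested is made for them only; others in the source may bear on it.

Compound 1, `Cc1cc(F)cc(Nc2cc(NC(=O)Nc3c(Cl)cccc3Cl)ncn2)c1`: 65.1%
Compound 2, `COc1ccc(Nc2cc(NC(=O)Nc3c(Cl)cccc3Cl)ncn2)cc1C`: 45.1%

Of the compounds shown here, two have been measured in a functional assay on NCI-H1581 cells (Homo sapiens) for inhibition, read by MTT assay, with a stated time of 48 h, tested at 10 uM; a higher number here means more inhibition at the concentration tested (going by the name of the read-out), a lower number less inhibition. Compound 2 stands lowest of the two numbers; its nearest neighbour is compound 1, which gives a higher number, beyond the scatter. Going by the values given here, the only measured step, a number 20 percentage points lower from compound 1 to compound 2 (beyond the scatter), swaps the aryl group on the nitrogen attached to the shared core and is the one step that bears on what comes next.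

Compound 3, `O=C(Nc1cc(Nc2ccc(F)c(Cl)c2)ncn1)Nc1c(Cl)cccc1Cl`, differs from compound 2 in exactly that place: 3-chloro-4-fluorophenyl in place of 4-methoxy-3-methylphenyl on a nitrogen on an aromatic ring. As with the measured step, the change replaces the ring that carries a methoxy group and a hydrogen-bond acceptor with a ring carrying only halogens, which resembles the direction from compound 2 back toward compound 1. A step in this assay of a size like a number 20 percentage points lower from compound 1 to compound 2 (beyond the scatter), but upward, is therefore expected, estimated as a number 12.9 percentage points higher from compound 2 to compound 3 (beyond the scatter). Compound 3 is expected to give about 58% in this assay, within a range from 40% to 75%.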

Compound 3, a percentage reported as inhibition, at one concentration (the size of the read-out at that concentration, not a potency): 67%
For compound 3 the middle estimate is 9 percentage points below the measured one; the measured number falls inside the stated range.
By their numbers in this assay, from the lowest: compound 2; then compounds 1 and 3 (each within the scatter of the next).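

In this assay, the ring on the nitrogen on an aromatic ring can move the number back up as well as down: 3-chloro-4-fluorophenyl in place of 4-methoxy-3-methylphenyl gives a number 21.9 percentage points higher from compound 2 to compound 3 (beyond the scatter) and shows that the earlier drop was not a one-way effect of changing this ring. Against the other halogen-bearing ring, 3-chloro-4-fluorophenyl in place of 3-fluoro-5-methylphenyl gives a number 1.9 percentage points higher from compound 1 to compound 3 (within the scatter), so this assay does not separate these two rings even though one carries a chlorine where the other carries a methyl group. Among these three compounds, only compound 2, with its methoxy group, stands apart, and no measurement given here explains why.

Going by these compounds, compound 2 differs from compound 3 at more than one point on the ring, so the share of the methoxy group, the methyl group and the halogens in this step remains open. Also open, on these data alone, is how a ring carrying an amine or a carboxylic acid in the same place would behave in this assay, where a single tested concentration gives the size of the read-out and not a potency.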